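Trimming ethyl to methyl: what compound 4 may show

The compounds below may be only part of what the source reports. "The series", "measured", "known", "first", "only" and "open" are said of these compounds alone.

In a physicochemical assay for solubility, read by HPLC, in simulated intestinal fluid, with a stated time of 16 h, at pH 6.5, tested at 2.5 mg/mL (on this read-out lower numbers stand for lower solubility and higher numbers for higher solubility), compound 3 (`CC[C@@]1(c2ccccc2)COc2c(C(=O)NC)cc(C(=O)N[C@H]3[C@@H]4COC[C@@H]43)cc21`) gives 93 ug/mL, the lowest of the numbers shown. Compound 1 (`CNC(=O)c1cc(C(=O)N[C@H]2[C@@H]3C[C@H](O)C[C@@H]32)cc2c1OC[C@@]2(C)c1ccccc1`) gives 539 ug/mL, a gap beyond the scatter. Compound 2 (`CNC(=O)c1cc(C(=O)N[C@H]2CC[C@H](O)CC2)cc2c1OC[C@@]2(C)c1ccccc1`) reads >= 1000 ug/mL, which is a limit of the assay and not a number.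

Compound 4 (`CNC(=O)c1cc(C(=O)N[C@H]2[C@@H]3COC[C@@H]32)cc2c1OC[C@@]2(C)c1ccccc1`) differs from compound 3 in one place: hydrogen in place of methyl on a saturated chain carbon bound to a saturated ring carbon. This is hydrogen in place of methyl on a saturated chain carbon bound to a saturated ring carbon, so ethyl becomes methyl. Among the compounds with values here, the only measured step, an at least 1.8-fold higher number from compound 1 to compound 2 (0.26 log units; that floor lies within the scatter), swaps a group on an amide-type nitrogen, so it does not measure this change. Compound 1 already has methyl in this place, but it also carries a different group on the amide-type nitrogen, so its 539 ug/mL is only a loose guide.

A modest rise is therefore expected in this assay, an estimated 2.2-fold higher number from compound 3 to compound 4 (0.33 log units; beyond the scatter). For compound 4 the expected value is 200 ug/mL, with an estimated range from 80 ug/mL to 500 ug/mL.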

Compound 4, solubility: 80 ug/mL
Compound 4: middle estimate off by 2.5-fold (0.40 log units), on the high side; low and high end bracket the measured number.
By their numbers in this assay, from the lowest: compounds 4 and 3 (each within the scatter of the next); then compound 1. At a limit, above all of these: compound 2.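

In this assay, trimming ethyl to methyl gives a 1.2-fold lower number from compound 3 to compound 4 (0.07 log units; within the scatter), so on this evidence the change at this position does not separate the two compounds. The group on the amide-type nitrogen makes the clearer difference, with a 6.7-fold lower number from compound 1 to compound 4 (0.83 log units; beyond the scatter) and an at least 12-fold lower number from compound 2 to compound 4 (1.09 log units; beyond the scatter). The number for compound 2 is a limit of the assay and not a measured value, so its step gives only a floor: the limit of >= 1000 ug/mL in this assay, at which 1 of the 4 values shown sits.

Within the data shown here, the ethyl to methyl change is seen with only one group on the amide-type nitrogen, so whether it stays this small with the groups of compound 1 or compound 2 remains open. Going by these compounds, how a longer chain such as propyl, or a chain carrying an amine or a carboxylic acid, would read in this place is also open.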